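This account rests on a few compounds, and the source may have more. Where it says the series, first, only, none or still open, it means among the compounds named here.

Compound 1 `COc1cc(/C=C/C(=O)c2cccc(-n3cc(-c4ccccc4)[nH]c3=O)c2)ccc1O` gives 2070 nM in a functional assay on SF-268 cells (Homo sapiens) for inhibition (on this read-out lower numbers stand for stronger inhibition of growth and higher numbers for weaker inhibition of growth), the lowest of the two numbers recorded; compound 2 `O=C(/C=C/c1cccc(O)c1)c1cccc(-n2cc(-c3ccccc3)[nH]c2=O)c1` gives 4530 nM, and the step of a 2.2-fold higher number from compound 1 to compound 2 (0.34 log units; beyond the scatter) came with a change on the double-bonded chain carbon. Compound 3 `COc1ccc(-c2cn(-c3cccc(C(=O)/C=C/c4ccc(O)c(OC)c4)c3)c(=O)[nH]2)cc1` instead alters the phenyl on the core of compound 1: methoxy in place of hydrogen on an aromatic carbon. Among the measured compounds shown here, no measured step touches that ring, so the one step known bears only loosely on this change, and no step beyond the scatter is expected, a 1.0-fold higher number from compound 1 to compound 3 (0.01 log units; within the scatter). Compound 3 is therefore estimated at 2100 nM, between 1000 nM and 4500 nM.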

Compound 3, concentration for 50% growth inhibition: 3400 nM
For compound 3 the middle estimate is 1.6-fold (0.21 log units) below the measured one; low and high end bracket the measured number.
By their numbers in this assay, from the lowest: compounds 1, 3 and 2 (each within the scatter of the next, the first and the last beyond it).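

In this assay, the change from phenyl to 4-methoxyphenyl on the core of compound 1 gives a 1.6-fold higher number from compound 1 to compound 3 (0.22 log units; within the scatter). Among the compounds shown here, this is the first measured change on that ring, and it shows that adding a methoxy para to a large group leaves the read-out within the usual scatter. No evidence on hand accounts for this result. The compounds shown leave open whether an amine, a carboxylic acid or a fluorine at this place would read the same, and whether the methoxy would do so alongside the 3-hydroxyphenyl of compound 2.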